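Exchange at the carbonyl carbon of compound 1

The source may report more compounds than this note shows. Statements on the series, on what has been measured and on what is new or still open speak of the compounds shown alone.

Measured so far:
compound 1 `O=C(Nc1ccc2nc(NC(=O)C3CCCCC3)sc2c1)c1cccc(F)c1`: 0.64 ug/mL
compound 2 `Cc1[nH][n+](C)c(C)c1C(=O)Nc1ccc2nc(NC(=O)C3CCCCC3)sc2c1`: 0.012 ug/mL

Compound 1 stands at the highest number of the two in a functional assay on WI-38 VA13 cells (Homo sapiens) for cytotoxicity; on this read-out lower numbers stand for an effect already at smaller amounts and higher numbers for an effect only at larger amounts of compound. For the measured compounds named here, the only measured step, a 53-fold lower number from compound 1 to compound 2 (1.73 log units; beyond the scatter), exchanged the 3-fluorophenyl on the carbonyl carbon for a ring of a different kind, and that step was large.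

Compound 3 `Cc1cccc(C)c1NC(=O)Nc1ccc2nc(NC(=O)C3CCCCC3)sc2c1` differs from compound 1 by (2,6-dimethylphenyl)amino in place of 3-fluorophenyl on a carbonyl carbon. The step from compound 1 to compound 2 touches the same carbonyl carbon, but the group it brought in shares nothing with the (2,6-dimethylphenyl)amino entering here, so it shows only that this place tolerates large change, not in which direction. Going by the values given here, no other step bears on the exchange. The expectation for compound 3 is therefore a number near that of compound 1, with a wide range, and a 1.3-fold lower number from compound 1 to compound 3 (0.11 log units; within the scatter) is the estimated step. Compound 3 is estimated at 0.5 ug/mL, between 0.08 ug/mL and 3 ug/mL.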

Compound 3, half-maximal effective concentration: 0.56 ug/mL
For compound 3 the middle estimate is 1.1-fold (0.05 log units) below the measured one; the measured number falls inside the stated range.
By their numbers in this assay, from the lowest: compound 2; then compounds 3 and 1 (each within the scatter of the next).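

In this assay, (2,6-dimethylphenyl)amino in place of 3-fluorophenyl on the carbonyl carbon gives a 1.1-fold lower number from compound 1 to compound 3 (0.06 log units; within the scatter) and so stays within the scatter, although the entering group brings a hydrogen-bond donor that 3-fluorophenyl lacks. Set against the five-membered ring of compound 2, the same group gives a 47-fold higher number from compound 2 to compound 3 (1.67 log units; beyond the scatter) and thus places compound 2 alone at the low end. This place therefore does not respond to every exchange: two different groups, each with a six-membered aromatic ring of carbon only, stand together, and only the five-membered ring stands apart.

Going by these compounds, whether other five-membered rings, or a morpholine or a carboxylic acid on this carbonyl carbon, would move the number remains open. Nothing at hand bears on the cause of either step.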